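Swapping carbamoyl for cyano on compound 2

The source may hold more compounds than are shown below. What is called first, only, known or untested is meant among the compounds shown, and "the series" means these compounds.

Compound 2, `COc1ccc(Cn2cc(C(N)=O)c3c(N)ncnc32)cc1`, gives 47000 nM in a functional assay on KB cells (Homo sapiens) for cytotoxicity (on this read-out lower numbers stand for stronger inhibition and higher numbers for weaker inhibition), the highest of the two numbers measured. Compound 1, `CC(C)(C)c1ccc(Cn2cc(C(N)=O)c3c(N)ncnc32)cc1`, gives 900 nM, a step of a 52-fold higher number from compound 1 to compound 2 (1.72 log units; beyond the scatter). Compound 3, `Cc1ccc(Cn2cc(C(N)=O)c3c(N)ncnc32)cc1`, reaches only the limit > 100000 nM, so its number is not known. The steps of an at least 110-fold higher number from compound 1 to compound 3 (2.04 log units; beyond the scatter) and an at least 2.1-fold higher number from compound 2 to compound 3 (0.32 log units; beyond the scatter) are limits as well. Compound 4, `COc1ccc(Cn2cc(C#N)c3c(N)ncnc32)cc1`, differs from compound 2 by cyano in place of carbamoyl on an aromatic carbon. All three measured steps exchange tert-butyl, methoxy or methyl on an aromatic carbon and leave the carbamoyl untouched, so none bears directly on this change. The number for compound 4 is therefore expected to change little, a 1.3-fold higher number from compound 2 to compound 4 (0.11 log units; within the scatter), a step not beyond the scatter. The estimate for compound 4 is 60000 nM, between 15000 nM and 200000 nM.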

Compound 4, half-maximal inhibitory concentration: > 100000 nM
Compound 4: only a limit was reported; the forecaster's own chance of this, stated with the estimate: 30%; middle value at least 1.6-fold (0.22 log units) away from the limit.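

In this assay compound 4 gives > 100000 nM, which is a limit and not a number. This is the first change shown at this aromatic carbon of the five-membered ring, and cyano in place of carbamoyl gives an at least 2.1-fold higher number from compound 2 to compound 4 (0.32 log units; beyond the scatter), so the swap weakens inhibition here. The true size of the step stays unknown, as it is only a bound set by the limit of the assay: the limit of > 100000 nM in this assay, at which 2 of the 4 values shown sit.

From the compounds shown here alone, it remains open how a carboxylic acid or an amine would read on this carbon. Also open, going by these compounds, is whether cyano would give the same result in a compound carrying tert-butyl in place of methoxy.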